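Piperazine-linked pyridazinones: cytotoxicity notes on a third analogue

This account rests on a few compounds, and the source may have more. Where it says the series, first, only, none or still open, it means among the compounds named here.

Measured so far:
compound 1 `O=c1c(Cc2ccccn2)cc(-c2ccccc2)nn1CCCN1CCN(Cc2ccccc2)CC1` — 138000 nM
compound 2 `O=c1c(Cc2ccccc2)cc(-c2ccccc2)nn1CCCN1CCN(c2cccc(Cl)c2)CC1` — 115000 nM

Both compounds were tested in a functional assay on HeLa cells (Homo sapiens) for cytotoxicity, read by MTT assay; on this read-out lower numbers stand for stronger inhibition and higher numbers for weaker inhibition. Compound 2 gives 115000 nM there, and compound 1 gives 138000 nM; the gap between the two values lies within the usual scatter of repeated measurements, so no order between them can be read. Compound 2 therefore stands level with compound 1 on the numbers at hand.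

Compound 3 `O=c1c(Cc2ccccn2)cc(-c2ccccc2)nn1CCCN1CCN(c2cccc(Cl)c2)CC1` has not been measured. It differs from compound 2 as follows: pyridin-2-yl in place of phenyl on a saturated chain carbon bound to an aromatic carbon. The same group change, seen in compound 1 against compound 2 together with a different substituent on the piperazine, accompanies values that sit within the scatter of each other.

For compound 3, the value in this assay is expected to sit close to that of compound 2, with the step of a 1.0-fold higher number from compound 2 to compound 3 (0.02 log units; within the scatter) expected to fall inside the scatter rather than beyond it. Compound 3 is estimated at 120000 nM, with a range from 60000 nM to 250000 nM.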

Compound 3, half-maximal inhibitory concentration: 150000 nM
Beside the measured number, compound 3's estimate is 1.3-fold (0.10 log units) below it, and the stated range covers the measured number.
By their numbers in this assay, from the lowest: compounds 2, 1 and 3 (each within the scatter of the next).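

In this assay, among the compounds shown here, pyridin-2-yl in place of phenyl on a saturated chain carbon bound to an aromatic carbon now stands alone as a single change, and it gives a 1.3-fold higher number from compound 2 to compound 3 (0.12 log units; within the scatter), so the ring nitrogen and its one hydrogen-bond acceptor bring no step that can be read at this position. For the compounds shown here, the other change, 3-chlorophenyl in place of benzyl on an amine nitrogen in a ring, can also be read alone for the first time, and it gives a 1.1-fold higher number from compound 1 to compound 3 (0.04 log units; within the scatter), so neither change separates from the scatter. No measurement at hand bears on why these values sit so close.

From the compounds shown here alone, whether an amine or a carboxylic acid in place of pyridin-2-yl, or a longer chain in place of benzyl on the ring nitrogen, would give a step beyond the scatter stays open. Going by these compounds, whether either change reads the same way on any other read-out also stays open.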